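Series notes: 2-methylphenyl to 2-chlorophenyl

The source may hold more compounds than are shown below. What is called first, only, known or untested is meant among the compounds shown, and "the series" means these compounds.

Values so far from a functional assay on MCF7 cells (Homo sapiens) for cytotoxicity, read by ELISA, with a stated time of 4 days (a higher number here means a weaker inhibitor, a lower number a stronger inhibitor), are these
- compound 1 `Cc1ccsc1-c1cc(-c2ccoc2)cc(-c2ccc(Cl)cc2)n1` gives 20300 nM
- compound 2 `Clc1ccc(-c2cc(-c3ccco3)cc(-c3ccc(Cl)s3)n2)cc1` gives 1520 nM
- compound 3 `Cc1ccccc1-c1cc(-c2ccoc2)cc(-c2ccc(Cl)s2)n1` gives 1430 nM

Compound 3 has a number within the scatter of compound 2 and far under that of compound 1, a gap beyond the scatter. Next comes compound 4 `Clc1ccc(-c2cc(-c3ccoc3)cc(-c3ccccc3Cl)n2)s1` with chloro in place of methyl on an aromatic carbon, ortho to a large group (chloro in place of methyl on an aromatic carbon). Among the compounds with values here, no measured pair isolates this change, and the three values give it no direction. In this assay a step within the scatter is expected, with neither direction favoured. The estimated step (a 1.0-fold lower number from compound 3 to compound 4 (0.01 log units; within the scatter)) is accordingly close to nil. Compound 4 is estimated at 1400 nM with an expected range of 550 nM to 3500 nM in this series.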

Compound 4, half-maximal inhibitory concentration: 7360 nM
Compound 4: middle estimate off by 5.3-fold (0.72 log units), on the low side; measured number outside the range, above it.
By their numbers in this assay, from the lowest: compounds 3 and 2 (each within the scatter of the next); then compound 4; then compound 1.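

Within the data shown here, this pair is the first to isolate a change at this position: in this assay chloro in place of methyl on an aromatic carbon, ortho to a large group, gives a 5.1-fold higher number from compound 3 to compound 4 (0.71 log units; beyond the scatter) with the rest of the molecule unchanged. The position therefore responds to the exchange of a single heavy atom, and methyl carries the lower number of the two. No measurement at hand accounts for the step.

Still open, going by these compounds, is how a methoxy group or an amine on the same carbon would read. On these data alone, it is also open whether the step recurs with other groups on the shared core.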